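The source may report more compounds than this note shows. Statements on the series, on what has been measured and on what is new or still open speak of the compounds shown alone.

In a functional assay on HepG2 cells (Homo sapiens) for cytotoxicity, with a stated time of 72 h (a lower number here means that less compound is needed, a higher number that more compound is needed for the effect), compound 1 `C=C[C@@](C)(/C=C/c1ccc(O)cc1)CCC(O)C(C)(C)O` gives > 52000 nM, which is a limit and not a number. Compound 2 `C=C[C@@](C)(/C=C/c1ccc(O)cc1)CC/C=C/C(=O)c1ccccc1` gives > 52000 nM, which is also a limit. Compound 1 therefore stands at the limit of > 52000 nM in this assay, at which 2 of the 2 values shown sit, and no measured number is available for comparison.

Compound 3 `C=C[C@@](C)(/C=C/c1ccc(O)cc1)CC/C=C(\C)C=O` keeps the core of compound 1 but carries 2-formylprop-1-en-1-yl in place of 1,2-dihydroxy-2-methylpropyl on a saturated chain carbon, three bonds along the chain from two double-bonded chain carbons. Going by the values given here, no step between measured compounds is available to guide the expectation. The estimated change, an at least 1.2-fold lower number from compound 1 to compound 3 (0.09 log units; that floor lies within the scatter), is expected to stay within the usual scatter, with no clear direction. This expectation rests only on (the limit of > 52000 nM in this assay, at which 2 of the 2 values shown sit). The expected value for compound 3 is 42000 nM, with an estimated range from 15000 nM to 80000 nM.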

Compound 3, half-maximal effective concentration: > 52000 nM
Compound 3: a limit, no number; the forecaster's own chance of this, stated with the estimate: 60%; at least 1.2-fold (0.09 log units) between middle value and limit.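

Going by these compounds alone, compound 3, like compound 1, gives only a limit in this assay, so no step from compound 1 to compound 3 can be read: the limit of > 52000 nM in this assay, at which 3 of the 3 values shown sit. The compounds shown leave open whether 1,2-dihydroxy-2-methylpropyl and 2-formylprop-1-en-1-yl differ at all in this assay.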